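The source may report more compounds than this note shows. Statements on the series, on what has been measured and on what is new or still open speak of the compounds shown alone.

In a functional assay on RT-112 cells (Homo sapiens) for antiproliferative activity, read by MTT assay, with a stated time of 72 h (on this read-out lower numbers stand for stronger inhibition of growth and higher numbers for weaker inhibition of growth), compound 1 `COc1cc(NC(=O)Nc2cccc3c(Nc4cc(OC)cc(OC)c4)ncnc23)cc(OC)c1` gives 366 nM, compound 3 `COc1cc(Nc2ncnc3c(NC(=O)Nc4cc(Cl)c(Cl)cc4Cl)cccc23)cc(OC)c1` gives 4890 nM, and compound 2 `COc1cc(Nc2ncnc3c(NC(=O)Nc4ccc(C)c(C)c4)cccc23)cc(OC)c1` gives 8.8 nM, the lowest of the three. Compound 4 `COc1cc(Nc2ncnc3c(NC(=O)Nc4cc(F)cc(F)c4)cccc23)cc(OC)c1` differs from compound 2 on an amide-type nitrogen, where 3,5-difluorophenyl stands in place of 3,4-dimethylphenyl: 3,5-difluorophenyl in place of 3,4-dimethylphenyl on an amide-type nitrogen. Two measured steps at this same place bear on the change, and both are large: a 42-fold lower number from compound 1 to compound 2 (1.62 log units; beyond the scatter), and a 560-fold higher number from compound 2 to compound 3 (2.74 log units; beyond the scatter). Compound 2 thus stands well below both other compounds, so a higher number is expected for the new group, although a 3,5-difluorophenyl group has not yet been measured and the size remains uncertain. The expected change is a 10-fold higher number from compound 2 to compound 4 (1.01 log units; beyond the scatter). For compound 4 the estimated value is 90 nM, with an expected range from 15 nM to 600 nM.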

Compound 4, concentration for 50% growth inhibition: 2630 nM
The estimate for compound 4 lay 29-fold (1.47 log units) below the measured number; measured number above the stated range.
By their numbers in this assay, from the lowest: compound 2; then compound 1; then compounds 4 and 3 (each within the scatter of the next).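

Although 3,5-difluorophenyl and 3,4-dimethylphenyl have the same heavy-atom count and ring, this exchange on the amide-type nitrogen sharply weakens growth inhibition in this assay (a 300-fold higher number from compound 2 to compound 4 (2.48 log units; beyond the scatter)). Thus, matching size alone does not preserve the low number of compound 2. The new group also falls short of 3,5-dimethoxyphenyl (a 7.2-fold higher number from compound 1 to compound 4 (0.86 log units; beyond the scatter)), while its gap to 2,4,5-trichlorophenyl stays within the scatter (a 1.9-fold lower number from compound 3 to compound 4 (0.27 log units; within the scatter)). Nothing available explains these differences.

Going by these compounds, whether the atoms on the ring or their arrangement matter more remains open. Comparing 3,4-difluorophenyl and 3,5-dimethylphenyl would help separate the two.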